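The compounds below may be only part of what the source reports. "The series", "measured", "known", "first", "only" and "open" are said of these compounds alone.

Measured so far:
- Compound 1 `CC1(C)CNC(=O)c2sc(Nc3ccc(I)cc3F)c(C(=O)NOCCO)c2C1` gives 340 nM in a functional assay on HT-29 cells (Homo sapiens) for antiproliferative activity; on this read-out higher numbers stand for weaker inhibition and lower numbers for stronger inhibition.
- Compound 2 `CC1(C)CNC(=O)c2sc(Nc3ccc(I)cc3F)c(C(=O)O)c2C1` gives "not determined" (no result reported) in this assay, that is, no result is reported for it.

Compound 2 carries a carboxy group on its shared core, and for it there is no number in this assay at all; where it stands on the potency scale is simply not known. Compound 1, with a different amide group on the same core, does have a result: in this assay compound 1 gives 340 nM.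

Compound 3 `CC1(C)CNC(=O)c2sc(Nc3ccc(I)cc3F)c(C(=O)N[C@@H]3CCCNC3)c2C1` is compound 2 with a single change: (piperidin-3-yl)amino in place of hydroxy on a carbonyl carbon. For the measured compounds named here, no step between two measured compounds matches this change, so the size and direction of any shift cannot be read from the data. Going by the values given here, with compound 2 unmeasured, the only anchor is compound 1, another amide on the same core.

Compound 3 is therefore expected to land near 300 nM, with a wide range from 60 nM to 1500 nM.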

Compound 3, half-maximal inhibitory concentration: 91 nM
Beside the measured number, compound 3's estimate is 3.3-fold (0.52 log units) above it, and the stated range covers the measured number.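

In this assay, placing piperidin-3-yl instead of 2-hydroxyethoxy on the amide-type nitrogen gives a 3.7-fold lower number from compound 1 to compound 3 (0.57 log units; beyond the scatter) and so shows that the group on this nitrogen can shift the read-out beyond the usual scatter, here towards stronger inhibition. The ring-bearing group, with its defined stereocentre, is thus compatible with activity at this position, but the step from compound 2 cannot be read: compound 2 has no number. Nothing available explains the shift in potency.

Going by these compounds, whether the ring itself, its nitrogen or its stereocentre matters remains open. The mirror-image piperidin-3-yl, a piperidin-4-yl group, a pyrrolidin-3-yl group or an open-chain 2-aminoethyl group on the same nitrogen would help separate these features.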